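Enantiomer of compound 3 in the amide series

This account rests on a few compounds, and the source may have more. Where it says the series, first, only, none or still open, it means among the compounds named here.

Three amides on a shared core have been run in an assay on SH-EP1 cells for agonist activity at Neuronal acetylcholine receptor; alpha4/beta2 (Homo sapiens), read by FLIPR and calcium flux; a higher number here means a larger maximal response, a lower number a smaller maximal response. Compound 1 `CC(=O)N1CC2CC(C1)N2` gives 95%; compound 2 `O=C(C1CCC1)N1CC2CC(C1)N2` gives 99%; compound 3 `C[C@@H]1C[C@H]1C(=O)N1CC2CC(C1)N2` gives 110%, the highest of the three, as the steps of a number 11 percentage points higher from compound 2 to compound 3 (beyond the scatter) and a number 15 percentage points higher from compound 1 to compound 3 (beyond the scatter) show, whereas the step is a number 4 percentage points higher from compound 1 to compound 2 (within the scatter). Compound 4 `C[C@H]1C[C@@H]1C(=O)N1CC2CC(C1)N2` keeps every atom and bond of compound 3 and differs only in configuration: the two compounds have the same atoms and bonds; at least one stereo element is drawn with a configuration in one of them and without one in the other: 2 of 4 stereo elements differ; a stereocentre at a saturated ring carbon is drawn R in compound 3 and S in compound 4; a stereocentre at a saturated ring carbon is drawn R in compound 3 and S in compound 4. Going by the values given here, none of the measured steps touches a stereocentre; each swaps the group on the carbonyl carbon, and the largest of them is only modest. Among the compounds with values here, no step therefore bears directly on this change, and the expected step of a number 8 percentage points lower from compound 3 to compound 4 (within the scatter) is none beyond the scatter, a small drop being possible. Compound 4 is estimated at 102%, range 85% to 118%.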

Compound 4, largest response reached (Emax), in percent of the reference or control that the assay uses: 85%
Compound 4: the middle estimate sits 17 percentage points above what was measured, and the stated range covers the measured number.
By their numbers in this assay, from the lowest: compounds 4, 1 and 2 (each within the scatter of the next, the first and the last beyond it); then compound 3.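

In this assay the configuration of the 2-methylcyclopropyl group on the carbonyl carbon moves the response by itself: with no atom changed, inversion gives a number 25 percentage points lower from compound 3 to compound 4 (beyond the scatter) here. The group as such does not raise the response, since the swaps give a number 14 percentage points lower from compound 2 to compound 4 (beyond the scatter) and a number 10 percentage points lower from compound 1 to compound 4 (within the scatter) and the earlier gain holds for one configuration only. One reservation applies to this pair: the fact that one of compounds 3 and 4 is drawn with a defined configuration and the other without, at the place where they differ.

Open, going by these compounds, is how an unsubstituted cyclopropyl or a 2-trifluoromethylcyclopropyl on the carbonyl carbon would read, and whether configuration matters as much there.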